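Aryl hydrazone variation on the shared core

This account rests on a few compounds, and the source may have more. Where it says the series, first, only, none or still open, it means among the compounds named here.

Measured compounds, an assay on CHO-K1 cells for displacement of a labelled ligand from adenosine receptor A1 (Homo sapiens), read by scintillation counting, with a stated time of 60 min; a lower number here means a stronger inhibitor, a higher number a weaker inhibitor:
compound 1 `N#Cc1ccc(/C=N/Nc2nc(N)c3ncn([C@@H]4O[C@H](CO)[C@@H](O)[C@H]4O)c3n2)cc1` gives 4.1 nM
compound 2 `CCCCc1nc(/C=N/Nc2nc(N)c3ncn([C@@H]4O[C@H](CO)[C@@H](O)[C@H]4O)c3n2)c(Cl)[nH]1` gives 12 nM
compound 3 `Nc1nc(N/N=C/c2cccnc2Cl)nc2c1ncn2[C@@H]1O[C@H](CO)[C@@H](O)[C@H]1O` gives 4.6 nM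

All three share one core and differ only in the group on a carbon with a double bond to nitrogen. Compound 3 holds the second highest of the three numbers. Its nearest neighbour is compound 1, with a 1.1-fold higher number from compound 1 to compound 3 (0.05 log units; within the scatter), a gap within the scatter; its furthest is compound 2, with a 2.6-fold lower number from compound 2 to compound 3 (0.42 log units; beyond the scatter). The remaining step is a 2.9-fold higher number from compound 1 to compound 2 (0.47 log units; beyond the scatter).

Compound 4 `N#Cc1ccccc1/C=N/Nc1nc(N)c2ncn([C@@H]3O[C@H](CO)[C@@H](O)[C@H]3O)c2n1` is the next to be measured in this assay. Its change from compound 3: 2-cyanophenyl in place of 2-chloropyridin-3-yl on a carbon with a double bond to nitrogen. The step that bears most directly on it is a 1.1-fold higher number from compound 1 to compound 3 (0.05 log units; within the scatter), which shows that exchanging 4-cyanophenyl for 2-chloropyridin-3-yl on this carbon leaves the number essentially where it was; the step of a 2.6-fold lower number from compound 2 to compound 3 (0.42 log units; beyond the scatter) shows that a modest shift is possible when a different ring enters. Nothing measured covers 2-cyanophenyl itself, so the position of the nitrile adds uncertainty. Going back from 2-chloropyridin-3-yl to a cyanophenyl is expected to give no step beyond the scatter, with compound 4 expected near compound 3 and compound 1.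

Compound 4 is estimated at 6 nM, with a range of 2 nM to 20 nM. The expected step is a 1.3-fold higher number from compound 3 to compound 4 (0.12 log units; within the scatter).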

Compound 4, inhibition constant: 2.9 nM
For compound 4 the middle estimate is 2.1-fold (0.32 log units) above the measured one; the range from low to high includes it.
By their numbers in this assay, from the lowest: compounds 4, 1 and 3 (each within the scatter of the next); then compound 2.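

The first reading of a moved nitrile on this carbon comes from this assay: 2-cyanophenyl in place of 4-cyanophenyl gives no step that can be told from the scatter (a 1.4-fold lower number from compound 1 to compound 4 (0.15 log units; within the scatter)), so the two nitrile placements shown cannot be separated. Replacing 2-chloropyridin-3-yl with 2-cyanophenyl also stays within the scatter (a 1.6-fold lower number from compound 3 to compound 4 (0.20 log units; within the scatter)), which means that a chlorine-bearing pyridine and a nitrile-bearing benzene ring are not told apart here, although the entering group has one more heavy atom and a triple bond. Compound 2 now stands further from the others, with the largest step in the series (a 4.1-fold lower number from compound 2 to compound 4 (0.62 log units; beyond the scatter)) and steps beyond the scatter to all three, leaving 2-butyl-5-chloro-1H-imidazol-4-yl as the one clear outlier among the four groups.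

Still open, from the compounds shown here alone, is whether 3-cyanophenyl, a plain phenyl, or a phenyl carrying an amine or a carboxylic acid would stay with compound 1, compound 3 and compound 4, and whether the gap of compound 2 follows its imidazole ring, its butyl chain or its chlorine. Nothing at hand gives a measured explanation for any of these numbers.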